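Methyl for methoxy on the amide aryl ring

The compounds below may be only part of what the source reports. "The series", "measured", "known", "first", "only" and "open" are said of these compounds alone.

In a functional assay on HCC1937 cells (Homo sapiens) for antiproliferative activity, read by CCK-8 assay, with a stated time of 72 h (a higher number here means a weaker inhibitor, a lower number a stronger inhibitor), compound 1 `COc1ccc(C(=O)Nc2cccc(-c3oc4cc(-c5ccc(F)cc5)ccc4c(=O)c3O)c2)cc1` gives 5490 nM as its value. Compound 2 `Cc1ccc(C(=O)Nc2cccc(-c3oc4cc(-c5ccc(F)cc5)ccc4c(=O)c3O)c2)cc1` gives 7110 nM in the same this assay runs; it differs from compound 1 by methyl in place of methoxy on an aromatic carbon and the step is a 1.3-fold higher number from compound 1 to compound 2 (0.11 log units; within the scatter) in size. Compound 3 `COc1cccc(C(=O)Nc2cccc(-c3oc4cc(-c5ccc(F)cc5)ccc4c(=O)c3O)c2)c1` gives 18900 nM in this assay and differs from compound 1 by 3-methoxyphenyl in place of 4-methoxyphenyl on a carbonyl carbon with a step of a 3.4-fold higher number from compound 1 to compound 3 (0.54 log units; beyond the scatter) in size, while against compound 2 the step is a 2.7-fold higher number from compound 2 to compound 3 (0.42 log units; beyond the scatter) in size. Compound 4 `Cc1cccc(C(=O)Nc2cccc(-c3oc4cc(-c5ccc(F)cc5)ccc4c(=O)c3O)c2)c1` awaits measurement in this assay and differs from compound 3 by methyl in place of methoxy on an aromatic carbon in structure. This is the same kind of change as that from compound 1 to compound 2, though the place differs: in the earlier pair the group sits para to a large group, here meta to a large group. The step from compound 3 to compound 4 is estimated at a 1.2-fold higher number from compound 3 to compound 4 (0.09 log units; within the scatter) in size, beside the earlier 1.3-fold higher number from compound 1 to compound 2 (0.11 log units; within the scatter) seen for compound 1, because a 1.3-fold higher number from compound 1 to compound 2 (0.11 log units; within the scatter) lay within the scatter. Compound 4 is thus expected near 23000 nM with a range from 9500 nM to 55000 nM in this assay terms.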

Compound 4, half-maximal inhibitory concentration: 8030 nM
Beside the measured number, compound 4's estimate is 2.9-fold (0.46 log units) above it, and the stated range ends above it.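

In this assay, methyl in place of methoxy gives a 2.4-fold lower number from compound 3 to compound 4 (0.37 log units; beyond the scatter), and this step does not match the one seen for the same change on the 4-methoxyphenyl amide: the same change on two cores in this assay, a 1.3-fold higher number (0.11 log units; within the scatter) from compound 1 to compound 2 and a 2.4-fold lower number (0.37 log units; beyond the scatter) from compound 3 to compound 4, 3.0-fold (0.48 log units) apart, beyond the scatter of two such steps

Among these compounds, the 3-methylphenyl amide shows no separation from the 4-methylphenyl amide, a 1.1-fold higher number from compound 2 to compound 4 (0.05 log units; within the scatter), or from the 4-methoxyphenyl amide, a 1.5-fold higher number from compound 1 to compound 4 (0.17 log units; within the scatter), which leaves compound 3 as the only member set apart, with its steps to all three others beyond the scatter. Among the compounds shown here, the comparison shows that the size and direction of this step cannot be assumed to carry from one of these amide aryl groups to the other, but with only two pairs in one cell line it does not show how the change behaves on any other core or why the two steps differ.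

As far as these compounds go, it remains open whether the result for compound 3 is specific to methoxy or extends to a longer ether such as ethoxy or to a hydroxyl group. Also open, from the compounds shown here alone, is whether an amine or a carboxylic acid on the same ring would track the methyl or the methoxy compounds.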